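The compounds below may be only part of what the source reports. "The series", "measured", "known", "first", "only" and "open" are said of these compounds alone.

Within the data shown here, compound 2 `CCCCCC(=O)c1ccc(OCCCN2CCN(S(=O)(=O)c3ccc(C#N)cc3)CC2)cc1` is one of two compounds measured in an assay on isolated protein for binding affinity to histamine H2 receptor (Homo sapiens) (a lower number here means a stronger inhibitor, a higher number a weaker inhibitor), so far. In this assay compound 2 gives 12300 nM, the highest of the two numbers. Among the measured compounds shown here, its nearest neighbour is compound 1 `CCCCCC(=O)c1ccc(OCCCN2CCN(C(=O)OCC(C)C)CC2)cc1`, which in this assay gives 3720 nM; the one step that separates them, a 3.3-fold higher number from compound 1 to compound 2 (0.52 log units; beyond the scatter), is the only measured step in this set.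

Compound 3 `CCCCCC(=O)c1ccc(OCCCN2CCN(C(=O)c3c[nH]cn3)CC2)cc1` has not yet been measured. It differs from compound 2 in one place: (1H-imidazol-4-yl)carbonyl in place of (4-cyanophenyl)sulfonyl on an amine nitrogen in a ring. The group that enters is a carbonyl-linked group, as in compound 1, whereas the group that leaves is sulfonyl-linked, as in compound 2. For the measured compounds named here, the measured step of a 3.3-fold higher number from compound 1 to compound 2 (0.52 log units; beyond the scatter) therefore bears on this change, although the group that enters is not the same as the one in compound 1, and it is a modest step.

On this basis compound 3 is expected to give a somewhat lower number than compound 2, a step estimated at a 3.1-fold lower number from compound 2 to compound 3 (0.49 log units; beyond the scatter). The estimate for compound 3 in this assay is 4000 nM, with a range from 1200 nM to 13000 nM.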

Compound 3, inhibition constant: 19500 nM
Estimate against measurement, compound 3: 4.9-fold (0.69 log units) below, outside the stated range (above it).
By their numbers in this assay, from the lowest: compound 1; then compounds 2 and 3 (each within the scatter of the next).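

In this assay, the step of a 1.6-fold higher number from compound 2 to compound 3 (0.20 log units; within the scatter) stays within the scatter, so the (1H-imidazol-4-yl)carbonyl and (4-cyanophenyl)sulfonyl groups on this amine nitrogen in a ring cannot be told apart, and a carbonyl link at this nitrogen does not by itself go with the lower number of compound 1. The step of a 5.2-fold higher number from compound 1 to compound 3 (0.72 log units; beyond the scatter), with 1H-imidazol-4-yl in place of isobutoxy on a carbonyl carbon, shows that the group on that carbonyl carbon matters at this position, leaving compound 1 apart from the other two. No measurement at hand accounts for either result.

The compounds shown leave open whether the lower number of compound 1 is specific to the isobutoxy group or would also be seen with a shorter chain such as ethoxy on the same carbonyl carbon. They also leave open whether an amine on that carbonyl carbon would fall with compound 1 or with compounds 2 and 3.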